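The source may hold more compounds than are shown below. What is called first, only, known or untested is meant among the compounds shown, and "the series" means these compounds.

Compound 2 `C[C@@H]1CCCN1c1c(C#N)c2c(N)nc(Nc3ccn(C)n3)cc2n1C` holds the lower of the two numbers in an assay on isolated protein for inhibition of Leucine-rich repeat serine/threonine-protein kinase 2 variant G2019S (Homo sapiens), read by TR-FRET and LanthaScreen, with stated times of 50 min and 30 min, in the presence of a further agent that is not named here (a higher number here means a weaker inhibitor, a lower number a stronger inhibitor), giving 206 nM, while compound 1 `Cc1cn(C)nc1Nc1cc2c(c(N)n1)c(C#N)c(N1CCC[C@H]1C)n2C` gives 1290 nM; the step of a 6.3-fold lower number from compound 1 to compound 2 (0.80 log units; beyond the scatter) arose from hydrogen in place of methyl on an aromatic carbon. Compound 3 `C[C@@H]1CCCN1c1c(C#N)c2c(N)nccc2n1C` differs from compound 2 by hydrogen in place of (1-methyl-1H-pyrazol-3-yl)amino on an aromatic carbon. Within the data shown here, no measured step removes this whole group, so the step of a 6.3-fold lower number from compound 1 to compound 2 (0.80 log units; beyond the scatter) bears on it only indirectly, and a much larger change is expected. The step from compound 2 to compound 3 is expected to be a 24-fold higher number from compound 2 to compound 3 (1.39 log units; beyond the scatter). Compound 3 is estimated at 5000 nM, with a likely range from 1000 nM to 30000 nM.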

Compound 3, half-maximal inhibitory concentration: 28 nM
Compound 3: middle estimate off by 180-fold (2.25 log units), on the high side; the measured number lies below the stated range.
By their numbers in this assay, from the lowest: compound 3; then compound 2; then compound 1.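

In this assay, this aromatic carbon needs no substituent to keep the number low: replacing the whole (1-methyl-1H-pyrazol-3-yl)amino group with hydrogen gives a 7.4-fold lower number from compound 2 to compound 3 (0.87 log units; beyond the scatter) and so does not weaken the compound. Replacing the (1,4-dimethyl-1H-pyrazol-3-yl)amino group with hydrogen goes further, giving a 46-fold lower number from compound 1 to compound 3 (1.66 log units; beyond the scatter) in the same direction. Neither of these two groups improves on plain hydrogen here, and nothing measured here explains this. Still open, going by these compounds, is whether something small at this carbon, such as a methyl, a fluorine or a plain amine, would lower the number further or raise it.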